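The compounds below may be only part of what the source reports. "The series", "measured", "known", "first", "only" and "open" are said of these compounds alone.

Notes on the series in a functional assay on NCI-H522 cells (Homo sapiens) for cytotoxicity, with a stated time of 3 days; a higher number here means a weaker inhibitor, a lower number a stronger inhibitor. Compound 1 (`C#Cc1nc(C(=O)OCC)cs1`) gives 2670 nM, compound 2 (`C#Cc1nc(-c2ccccc2)cs1`) gives 5650 nM, and compound 3 (`Ic1nc2ccccc2o1`) gives 11700 nM. Compound 3 has the highest number of the three, beyond the scatter from both others. Compound 4 (`C=Cc1nc2ccccc2o1`) has vinyl in place of iodo on an aromatic carbon, next to the ring nitrogen and next to the ring oxygen: vinyl in place of iodo on an aromatic carbon. Among the compounds with values here, no measured pair shows a change at this place, so the size of the step remains uncertain. A modest move towards a lower number is expected, perhaps not beyond the scatter. The expected change is a 1.5-fold lower number from compound 3 to compound 4 (0.17 log units; within the scatter). For compound 4 the estimated value is 8000 nM, with an expected range of 3500 nM to 18000 nM.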

Compound 4, half-maximal inhibitory concentration: > 40000 nM
Compound 4: a limit, no number; the forecaster's own chance of this, stated with the estimate: 8%; middle value at least 5.0-fold (0.69 log units) from the limit.
By their numbers in this assay, from the lowest: compound 1; then compound 2; then compound 3. At a limit, above all of these: compound 4.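

In this assay compound 4 reads > 40000 nM, which is a limit and not a number. The aromatic carbon next to the ring nitrogen and next to the ring oxygen is thus sensitive to change: vinyl in place of iodo gives an at least 3.4-fold higher number from compound 3 to compound 4 (0.53 log units; beyond the scatter), the first step read at this place and one beyond the scatter. The step has a lower bound only, and its full size stays unknown: the limit of > 40000 nM in this assay, at which 1 of the 4 values shown sits.

Only iodo and vinyl are shown at this place. From the compounds shown here alone, whether an amine, a methoxy group or a longer chain on this carbon would keep a measurable number remains open.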